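Trifluorophenyl Variant of a Piperidine-Linked Carboline Series

A few compounds are considered here, and "the series" means these few. Any claim that something is new, unique, unknown or untested is made for them only; others in the source may bear on it.

Measured compounds:
compound 1, `COc1ccc2[nH]c3c(c2c1)CCNC31CCN(Cc2ccc([N+](=O)[O-])cc2F)CC1`, 5900 nM
compound 2, `COc1ccc2[nH]c3c(c2c1)CCNC31CCN(Cc2ccc(Cl)cc2Cl)CC1`, 1800 nM
compound 3, `COc1ccc2[nH]c3c(c2c1)CCNC31CCN(Cc2cc(F)ccc2F)CC1`, 11100 nM

In an assay on FRT cells for positive allosteric modulation of Cystic fibrosis transmembrane conductance regulator variant N1303K (Homo sapiens), in the presence of a further agent that is not named here (a higher number here means that more compound is needed for the effect, a lower number that less compound is needed), compound 1 stands second highest of the three numbers, with compound 3 nearest and compound 2 furthest. Compound 4, `COc1ccc2[nH]c3c(c2c1)CCNC31CCN(Cc2ccc(F)c(F)c2F)CC1`, differs from compound 1 by 2,3,4-trifluorophenyl in place of 2-fluoro-4-nitrophenyl on a saturated chain carbon bound to an amine nitrogen in a ring. Two measured steps also change this group: a 3.3-fold lower number from compound 1 to compound 2 (0.52 log units; beyond the scatter) and a 1.9-fold higher number from compound 1 to compound 3 (0.27 log units; within the scatter), while a 6.2-fold higher number from compound 2 to compound 3 (0.79 log units; beyond the scatter) shows that the halogen pattern alone can move the number beyond the scatter. Replacing the nitro-bearing ring with a halogenated ring thus gave either a modest drop or a change within the scatter, so compound 4 is expected to land near compound 1, with a 1.1-fold lower number from compound 1 to compound 4 (0.03 log units; within the scatter). Compound 4 is estimated at 5500 nM, with a range of 1800 nM to 17000 nM.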

Compound 4, half-maximal effective concentration: 4100 nM
The estimate for compound 4 lay 1.3-fold (0.13 log units) above the measured number; low and high end bracket the measured number.
By their numbers in this assay, from the lowest: compound 2; then compounds 4, 1 and 3 (each within the scatter of the next, the first and the last beyond it).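

The 2,3,4-trifluorophenyl group shows that a ring bearing only fluorine can match the 2-fluoro-4-nitrophenyl group at this position (a 1.4-fold lower number from compound 1 to compound 4 (0.16 log units; within the scatter)). Among the halogenated rings, the fluorine pattern matters (a 2.7-fold lower number from compound 3 to compound 4 (0.43 log units; beyond the scatter)), while the 2,4-dichlorophenyl group still gives the lower number (a 2.3-fold higher number from compound 2 to compound 4 (0.36 log units; beyond the scatter)). Nothing available here explains these shifts. The compounds shown leave open how a methoxy group or a nitrile on this ring would compare, and whether a trichlorophenyl ring would move the number further than the 2,4-dichlorophenyl group.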